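Fluoro step on two cores: antiproliferative working notes

The source may hold more compounds than are shown below. What is called first, only, known or untested is meant among the compounds shown, and "the series" means these compounds.

compound 1 `Cc1nn2c(-c3nc4cc(Cl)c(Cl)cc4[nH]3)c(-c3ccccc3)nc2s1`: 19100 nM
compound 2 `Cc1nn2c(-c3nc4cc(Cl)c(Cl)cc4[nH]3)c(-c3ccc(F)cc3)nc2s1`: > 30000 nM
compound 3 `Cc1ccc(-c2nc3sc(C)nn3c2-c2nc3cc(Cl)ccc3[nH]2)cc1`: 7300 nM

In a functional assay on DU-145 cells (Homo sapiens) for antiproliferative activity, read by MTT assay (on this read-out higher numbers stand for weaker inhibition and lower numbers for stronger inhibition), compound 1 gives 19100 nM. Compound 2 reaches only the assay limit, > 30000 nM, so no number is available for it. Compound 3 gives 7300 nM, the lowest of the two numbers available, and its gap to compound 1 lies beyond the scatter. Compound 3 and compound 1 differ in more than one place; the difference between the two cores is not broken down here.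

The change fluoro in place of hydrogen on an aromatic carbon produced an at least 1.5-fold higher number from compound 1 to compound 2 (0.19 log units; that floor lies within the scatter). That floor rests on (the limit of > 30000 nM in this assay, at which 1 of the 3 values shown sits), so the true size of the step is open. Compound 4 `Cc1ccc(-c2nc3sc(C)nn3c2-c2nc3cc(Cl)c(F)cc3[nH]2)cc1` carries the same kind of change on the core of compound 3, (fluoro in place of hydrogen on an aromatic carbon). The place is not the same: in compound 2 the fluoro sits on a six-membered aromatic ring of carbon only, para to a large group, whereas in compound 4 it sits on a ring that is part of a fused or bridged system of two rings, ortho to a chloro group, meta to a fused ring and para to a fused ring. Given the direction of the earlier step, compound 4 is expected to move by a 1.4-fold higher number from compound 3 to compound 4 (0.14 log units; within the scatter) in this assay. The estimate for compound 4 is 10000 nM, within a range from 4000 nM to 28000 nM.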

Compound 4, half-maximal inhibitory concentration: 11800 nM
The estimate for compound 4 lay 1.2-fold (0.07 log units) below the measured number, and the stated range covers the measured number.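

In this assay, fluoro in place of hydrogen on an aromatic carbon comes out as a 1.6-fold higher number from compound 3 to compound 4 (0.21 log units; within the scatter), so compound 3 and compound 4 cannot be told apart on this read-out. Set beside the earlier step, this second reading adds no firm effect on either core: the same change on two cores in this assay, an at least 1.5-fold higher number (0.19 log units; that floor lies within the scatter) from compound 1 to compound 2 and a 1.6-fold higher number (0.21 log units; within the scatter) from compound 3 to compound 4; the limit leaves it open whether they differ The two steps do not show that the change carries from one core to another as a single effect; the fluoro sits on a six-membered aromatic ring of carbon only in compound 2, and on a ring that is part of a fused system, ortho to a chloro group, in compound 4.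

Still open, going by these compounds, is the true size of the step to compound 2, which rests on a limit of the assay. Also open, on these data alone, is whether another group in place of that hydrogen, such as an amine, a methoxy group or a carboxylic acid, would give a step beyond the scatter on either core.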